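Methyl Capping of a Phenol in a Topoisomerase Series

The source may report more compounds than this note shows. Statements on the series, on what has been measured and on what is new or still open speak of the compounds shown alone.

Measured compounds:
- compound 1, `COc1ccc(-c2cc3ccccc3c(-c3cccc(OC)c3)n2)cc1`: 43.2%
- compound 2, `COc1ccc(-c2cc3ccccc3c(-c3cccc(N)c3)n2)cc1`: 0%
- compound 3, `COc1cc(OC)cc(-c2cc3ccccc3c(-c3cccc(O)c3)n2)c1`: 0%

Of the compounds shown here, three sharing one core have been tested in an assay on isolated protein for inhibition of DNA topoisomerase 1 (Homo sapiens), with a stated time of 30 min, tested at 100 uM; on this read-out lower numbers stand for a weaker effect and higher numbers for a stronger effect at the one concentration tested. Compound 1 gives 43.2% in this assay, while compound 2 gives 0% and compound 3 gives 0%. Compound 3 therefore sits level with compound 2 at the digits reported, the two together forming the lowest pair of the three numbers, and it lies well beneath compound 1.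

Compound 4, `COc1cc(OC)cc(-c2cc3ccccc3c(-c3cccc(OC)c3)n2)c1`, is not yet measured. It differs from compound 3 in one place: methyl in place of hydrogen on an oxygen on an aromatic ring. Among the measured compounds shown here, the single measured step, a number 43.2 percentage points lower from compound 1 to compound 2 (beyond the scatter), concerns a different change on the same ring, replacing methoxy with amino, and it shows that removing the methoxy there costs a large amount of inhibition. Compound 1 and compound 3 differ in two places, so their values can only be compared as they stand. Restoring a methoxy on that ring in compound 4 is thus expected to lift the read-out partly towards compound 1, an increase estimated at a number 20 percentage points higher from compound 3 to compound 4 (beyond the scatter). The expected value for compound 4 in this assay is 20%, with a range from 0% to 45%.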

Compound 4, a percentage reported as inhibition, at one concentration (the size of the read-out at that concentration, not a potency): 0%
The estimate for compound 4 lay 20 percentage points above the measured number, and the stated range covers the measured number.
By their numbers in this assay, from the lowest: compounds 2, 3 and 4 (each within the scatter of the next); then compound 1.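

In this assay, capping the phenol gives no change at the digits printed from compound 3 to compound 4 (within the scatter), so on this scaffold the change from 3-hydroxyphenyl to 3-methoxyphenyl does not by itself restore any measurable inhibition, and both compounds stay at the bottom of the read-out. Among the compounds shown here, the earlier step from compound 1 to compound 2 had pointed to the methoxy as important, but the 3-methoxyphenyl group of compound 1 is also carried by compound 4, and compound 4 still gives 0%, which shows that this group is not sufficient when the other aromatic group on the shared core is the one found in compound 3 and compound 4. No measurement is available here that would explain this absence of change.

The compounds shown leave open whether this position matters at all with the other aromatic group of compound 1 in place, since the hydroxy partner of compound 1 does not appear among them. They also leave open how a 4-methoxyphenyl group, or an ethoxy group or a carboxylic acid at the position of the methoxy, would read alongside the pattern of compound 4.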